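A Fluorine for a Methoxy on the Ring-Nitrogen Aryl

The source may report more compounds than this note shows. Statements on the series, on what has been measured and on what is new or still open speak of the compounds shown alone.

Of the compounds shown here, three built on one shared core have been measured in a functional assay on HOS cells (Homo sapiens) for inhibition, read by CCK-8 assay, with a stated time of 72 h, tested at 1 uM; on this read-out lower numbers stand for less inhibition and higher numbers for more inhibition at the one concentration tested (going by the name of the read-out). Compound 1 `COc1ccccc1N1C(=O)CSC1c1cc(F)cc(C(=O)O)c1` gives 8% in this assay. Compound 2 `COc1ccc(OC)c(N2C(=O)CSC2c2cccc(C(=O)NCCCCc3ccccc3)c2)c1` gives 5% in this assay. Compound 3 `CCOc1ccccc1N1C(=O)C(C)SC1c1cccc(C(=O)NCCCCc2ccccc2)c1` gives 82% in this assay. Among these three numbers compound 2 stands lowest; its nearest neighbour is compound 1, whose number sits within the scatter of it, so no order between those two can be read, while its furthest neighbour is compound 3, whose number lies well beyond the scatter.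

Compound 4 `COc1cc(F)ccc1N1C(=O)CSC1c1cccc(C(=O)NCCCCc2ccccc2)c1` has not yet been measured in this assay. It differs from compound 2 in one place: 4-fluoro-2-methoxyphenyl in place of 2,5-dimethoxyphenyl on an amide-type nitrogen in a ring. Within the data shown here, no pair of measured compounds differs by this change alone, so its effect cannot be taken from the data; compound 3 differs from compound 2 in more than this one place and gives no clean guide. The step from compound 2 to compound 4 in this assay is expected to be an increase of moderate size, around a number 20 percentage points higher from compound 2 to compound 4 (beyond the scatter), though it may stay within the scatter. Compound 4 is therefore expected to give about 25% in this assay, within a range from 0% to 65%.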

Compound 4, a percentage reported as inhibition, at one concentration (the size of the read-out at that concentration, not a potency): 81%
Beside the measured number, compound 4's estimate is 56 percentage points below it; the whole stated range lies below it.
By their numbers in this assay, from the lowest: compounds 2 and 1 (each within the scatter of the next); then compounds 4 and 3 (each within the scatter of the next).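

In this assay the change gives a number 76 percentage points higher from compound 2 to compound 4 (beyond the scatter), so a swap at this one place, on the amide-type nitrogen in a ring, is enough on its own to move the read-out by a large amount while the rest of compound 2 stays as it is. Among these compounds, no two earlier compounds differed in one place only, so they could not assign any share of the spread in their numbers to the aryl group on this nitrogen; this pair now shows that the group matters strongly for inhibition at the one concentration tested. Nothing available explains why 4-fluoro-2-methoxyphenyl and 2,5-dimethoxyphenyl differ so much here.

The step removes a methoxy group and brings in a fluorine at the same time, so the compounds shown leave open whether the loss, the gain or both together carry it. Also open, going by these compounds, is how the number would respond to a plain 2-methoxyphenyl on this nitrogen, or to a chlorine or an amine in the place of the fluorine.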